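Swapping fluoro for methoxy on a weakly active series

The source may hold more compounds than are shown below. What is called first, only, known or untested is meant among the compounds shown, and "the series" means these compounds.

Measured so far in a functional assay on SK-HEP1 cells (Homo sapiens) for antiproliferative activity; on this read-out higher numbers stand for weaker inhibition of growth and lower numbers for stronger inhibition of growth:
compound 1 `COc1ccc(/C(COc2ccc3c(=O)c(-c4ccccc4)coc3c2)=N\O)cc1` gives 5510000 nM;
compound 2 `CO/N=C(/COc1ccc2c(=O)c(-c3ccccc3)coc2c1)c1ccccc1` gives 7400000 nM;
compound 3 `CO/N=C(/COc1ccc2c(=O)c(-c3ccccc3)coc2c1)c1ccc(F)cc1` gives 6100000 nM.

All three numbers are very high, meaning the compounds barely slow the growth of these cells. Compound 3 stands second highest of the three, but its nearest neighbour is compound 1, and its furthest is compound 2, and both of those gaps are within the scatter, so the three values cannot be told apart.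

Compound 4 `CO/N=C(/COc1ccc2c(=O)c(-c3ccccc3)coc2c1)c1ccc(OC)cc1` has not yet been measured. It differs from compound 3 in one place: methoxy in place of fluoro on an aromatic carbon, on an aromatic carbon of a six-membered aromatic ring of carbon only, para to a large group.

Among the compounds with values here, only one measured step bears on this position: a 1.2-fold lower number from compound 2 to compound 3 (0.08 log units; within the scatter), which shows that changing the group there from hydrogen to fluoro left the number essentially where it was. Compound 1, which carries a methoxy on the same ring but a different oxime, also sits within the scatter of compound 3. Nothing here points to a real change, so the expected step of a 1.0-fold lower number from compound 3 to compound 4 (0.01 log units; within the scatter) is none beyond the scatter.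

Compound 4 is therefore expected to give about 6000000 nM in this assay, with a likely range from 3000000 nM to 12000000 nM.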

Compound 4, concentration for 50% growth inhibition: 5300000 nM
Compound 4: middle estimate off by 1.1-fold (0.05 log units), on the high side; low and high end bracket the measured number.
By their numbers in this assay, from the lowest: compounds 4, 1, 3 and 2 (each within the scatter of the next).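

Methoxy on this aromatic carbon, para to a large group, gives no change that can be told from the scatter in this assay: the step from fluoro is small (a 1.2-fold lower number from compound 3 to compound 4 (0.06 log units; within the scatter)), and so is the step from hydrogen (a 1.4-fold lower number from compound 2 to compound 4 (0.14 log units; within the scatter)). Together with the earlier step from hydrogen to fluoro, this means that hydrogen, fluoro and methoxy at this place cannot be told apart, so the flat result seen with fluoro also holds for a group with more heavy atoms and a hydrogen-bond acceptor. The new compound also allows a one-place comparison at the oxime oxygen, where methyl in place of hydrogen likewise stays within the scatter (a 1.0-fold lower number from compound 1 to compound 4 (0.02 log units; within the scatter)), but no measurement at hand explains why these changes leave the number where it is.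

The compounds shown leave open whether an amine or a carboxylic acid at this ring position would move the number beyond the scatter. They also leave open whether a longer chain in place of the methyl on the oxime oxygen would do so.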